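Methoxy in Place of Fluoro: Estimating Compound 4

A few compounds are considered here, and "the series" means these few. Any claim that something is new, unique, unknown or untested is made for them only; others in the source may bear on it.

Compound 1 `COc1ccc(C(=O)C(CC(=O)c2ccc(Cl)cc2)c2cn(-c3ccc(Cl)cc3)nc2-c2ccc(C)cc2)cc1` gives 16.1% in this assay.
Compound 2 `Cc1ccc(-c2nn(-c3ccc(S(N)(=O)=O)cc3)cc2C(CC(=O)c2ccc(Cl)cc2)C(=O)c2ccc(F)cc2)cc1` gives 53.5%.
Compound 3 `Cc1ccc(-c2nn(-c3ccc(Cl)cc3)cc2-c2cc(-c3ccc(Cl)cc3)[nH]c2-c2ccc(F)cc2)cc1` gives 38.3%.

Of the compounds shown here, three have been measured in a functional assay on the whole organism (strain Wistar albino) for inhibition, with Rattus norvegicus as the target, read by paw edema, with stated times of 1 h and 2 h, at a dose of 0.32 mmol/kg by the intraperitoneal route; a higher number here means more inhibition at the dose given (going by the name of the read-out), a lower number less inhibition. Compound 3 stands second of the three numbers: its nearest neighbour is compound 2, whose number is higher by a gap beyond the usual scatter, and the furthest is compound 1, whose number is lower, again by a gap beyond the scatter. For the measured compounds named here, compound 1 and compound 2 are built on a different core from compound 3, so no step between measured compounds describes a single change.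

Compound 4 `COc1ccc(-c2[nH]c(-c3ccc(Cl)cc3)cc2-c2cn(-c3ccc(Cl)cc3)nc2-c2ccc(C)cc2)cc1` is the next compound and keeps the core of compound 3. It differs in one place: methoxy in place of fluoro on an aromatic carbon. Going by the values given here, no measured pair shows this change, so the expectation rests on compound 3 alone. The step from compound 3 to compound 4 is expected to be small, likely within the scatter, with no firm direction: a number 2.3 percentage points lower from compound 3 to compound 4 (within the scatter). Compound 4 is therefore estimated at 36%, with a range from 22% to 50%.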

Compound 4, a percentage reported as inhibition, in the whole organism at one dose (the size of the read-out at that dose, not a potency): 9.38%
Compound 4: the middle estimate sits 26.6 percentage points above what was measured, outside the stated range (below it).
By their numbers in this assay, from the lowest: compounds 4 and 1 (each within the scatter of the next); then compound 3; then compound 2.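

In this assay, the change from 4-fluorophenyl to 4-methoxyphenyl gives a number 28.9 percentage points lower from compound 3 to compound 4 (beyond the scatter) and so turns out not to be a neutral swap on this core. The earlier compounds shown here could not show this, since none of them formed a pair differing in one place; this position, on a six-membered aromatic ring of carbon only and para to a large group, now has a measured bearing on the inhibition seen at this dose. Nothing at hand accounts for the loss, so the step stands as an observation only.

One pair cannot say whether the loss follows from the arrival of methoxy or the departure of fluoro, and a hydroxyl group, an amine or an ethoxy group at the same place would help separate the two. From the compounds shown here alone, whether the same change would act alike on the core of compound 1 also stays open.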